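Sulfo in place of 2-carboxyethenyl on the shared core

This account rests on a few compounds, and the source may have more. Where it says the series, first, only, none or still open, it means among the compounds named here.

In a functional assay (thoracic aorta) for inhibition, with Rattus norvegicus as the target (a higher number here means a weaker inhibitor, a lower number a stronger inhibitor), compound 3 `CC(C)c1ccc2c(/C=C/C(=O)O)cc(CCCCNS(=O)(=O)c3ccccc3)c-2cc1` stands at 21000 nM as the weakest of the three measured inhibitors, well behind compound 1 `CC(C)c1ccc2c(CCCCNS(=O)(=O)c3ccccc3)cc(C(=O)O)c-2cc1` at 70 nM and compound 2 `CC(C)c1ccc2c(CCCCNS(=O)(=O)c3ccccc3)cc(CC(=O)O)c-2cc1` at 300 nM on the same scale. Compound 4 `CC(C)c1ccc2c(CCCCNS(=O)(=O)c3ccccc3)cc(S(=O)(=O)O)c-2cc1` carries sulfo in place of 2-carboxyethenyl on an aromatic carbon, and the counted change sulfo in place of 2-carboxyethenyl on an aromatic carbon leaves the rest of the core as it is.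

Three measured steps at this same aromatic carbon bear on the change. Carboxymethyl in place of carboxy gives a 4.3-fold higher number from compound 1 to compound 2 (0.63 log units; beyond the scatter) as a modest loss, 2-carboxyethenyl in place of carboxy gives a 300-fold higher number from compound 1 to compound 3 (2.48 log units; beyond the scatter) as a large loss, and 2-carboxyethenyl in place of carboxymethyl gives a 70-fold higher number from compound 2 to compound 3 (1.85 log units; beyond the scatter) as another large loss. Among the measured compounds shown here, no measured compound carries sulfo, so the read-across is partial. Sulfo is attached straight to the aromatic carbon, as carboxy is in compound 1 at 70 nM on the same scale, so most of the loss seen with 2-carboxyethenyl is expected to be recovered. The expected move is large and towards a lower number, estimated as a 140-fold lower number from compound 3 to compound 4 (2.15 log units; beyond the scatter) in this assay for this replacement. Compound 4 is estimated at 150 nM with an expected range of 30 nM to 900 nM on the half-maximal inhibitory concentration read-out.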

Compound 4, half-maximal inhibitory concentration: 17 nM
Compound 4: middle estimate off by 8.8-fold (0.95 log units), on the high side, and the stated range ends above it.
By their numbers in this assay, from the lowest: compound 4; then compound 1; then compound 2; then compound 3.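

In this assay, among the compounds shown here, sulfo on this aromatic carbon gives the lowest number of the four compounds, and the step of a 4.1-fold lower number from compound 1 to compound 4 (0.61 log units; beyond the scatter) is the first measured move from carboxy at this position that goes towards a lower number rather than a higher one. Against the groups that put carbon between the aromatic carbon and the acid function the gaps are wider, with an 18-fold lower number from compound 2 to compound 4 (1.25 log units; beyond the scatter) for carboxymethyl and a 1200-fold lower number from compound 3 to compound 4 (3.09 log units; beyond the scatter) for 2-carboxyethenyl. Carboxy and sulfo, both attached straight to the aromatic carbon, now each give lower numbers than carboxymethyl and 2-carboxyethenyl, and none of the four compounds goes against this, so a carboxylic acid directly on this carbon is not the only group that gives a low number here.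

Still open, on these data alone, is how a tetrazole, a phosphonic acid or a primary sulfonamide on this aromatic carbon would rank against sulfo and carboxy, and whether sulfo would keep its lead with a shorter or longer chain on the sulfonamide side of the core. Nothing shown here gives a measured reason for the gain from sulfo over carboxy.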